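Trimming the Branch: Isopropyl to Ethyl on the Hydrazone

A few compounds are considered here, and "the series" means these few. Any claim that something is new, unique, unknown or untested is made for them only; others in the source may bear on it.

Of the compounds shown here, three share a common core and have been tested in a functional assay on CCRF-CEM cells (Homo sapiens) for antiproliferative activity, read by MTT assay; on this read-out lower numbers stand for stronger inhibition and higher numbers for weaker inhibition. Compound 1, `c1ccc(C(=NNc2nc3ccccc3o2)c2ccccn2)nc1`, gives 44 nM in this assay. Compound 2, `C/C(=N\Nc1nc2ccccc2o1)c1cc(C)ncn1`, gives 230 nM. Compound 3, `CC(C)/C(=N\Nc1nc2ccccc2o1)c1ccccn1`, gives 21 nM, the lowest number of the three; compound 1 sits nearest to it, a gap beyond the usual scatter, and compound 2 sits furthest away, also beyond the scatter. Among the compounds with values here, since no single-point steps connect these three, their numbers can only be placed side by side, not traced to one change.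

Compound 4, `CC/C(=N\Nc1nc2ccccc2o1)c1ccccn1`, has not yet been measured in this assay. It differs from compound 3 in one place: hydrogen in place of methyl on a saturated chain carbon bound to a carbon with a double bond to nitrogen and a saturated chain carbon. Seen one bond further out, the isopropyl group has become an ethyl group.

Nothing measured here shows directly how this assay responds to such a change. The difference is a single carbon on a short chain, and compound 3 already stands at the low end. A small step is expected, if any, perhaps slightly toward a higher number, within the scatter: a 1.4-fold higher number from compound 3 to compound 4 (0.15 log units; within the scatter). Compound 4 is therefore expected to give about 30 nM, likely between 12 nM and 80 nM.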

Compound 4, half-maximal inhibitory concentration: 4 nM
For compound 4 the middle estimate is 7.5-fold (0.88 log units) above the measured one, outside the stated range (below it).
By their numbers in this assay, from the lowest: compound 4; then compound 3; then compound 1; then compound 2.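

Trimming isopropyl to ethyl gives, in this assay, a 5.3-fold lower number from compound 3 to compound 4 (0.72 log units; beyond the scatter), the first change in this set that can be read on its own. It shows that this place on the chain is not silent: taking away a single carbon moves the number clearly, and toward stronger inhibition rather than weaker. For this pair, then, the isopropyl branch is not needed for the low number of compound 3, and the ethyl group of compound 4 does better, though nothing at hand explains why the number falls.

The compounds shown leave open whether the trend carries on to a smaller group at this place or reverses with a longer chain such as propyl, or with a ring such as cyclopropyl, since one step gives only two points and no direction beyond them. Going by these compounds, compound 1 and compound 2 differ from compound 4 in more than one place, so their gaps cannot be read as the effect of any single change, and it also remains open whether the same trimming would help on their cores.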